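Removing a Chloro Group From a Cytotoxic Chloroacetamide

The source may hold more compounds than are shown below. What is called first, only, known or untested is meant among the compounds shown, and "the series" means these compounds.

Measured compounds:
- Compound 1, `O=C(CSC(=S)N[C@H]1CCOC1=O)Nc1ccc(Cl)cc1`: 50300 nM
- Compound 2, `O=C(CSC(=S)N[C@H]1CCOC1=O)Nc1ccc(Cl)cc1Cl`: 29200 nM
- Compound 3, `O=C(CCl)Nc1ccc(C(=O)/C=C/c2ccc(Cl)cc2)cc1`: 4100 nM

All three were tested in a functional assay on MCF7 cells (Homo sapiens) for cytotoxicity, read by MTT assay, with a stated time of 72 h; a higher number here means a weaker inhibitor, a lower number a stronger inhibitor. Compound 1 and compound 2 share one core; compound 3 has a different core, and the difference between the two cores is not broken down here. Compound 3 gives the lowest number of the three, and its gap to both compound 2 and compound 1 lies beyond the usual scatter.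

Compound 4, `O=C(CCl)Nc1ccc(C(=O)/C=C/c2ccccc2)cc1`, has not yet been measured. It differs from compound 3 by hydrogen in place of chloro on an aromatic carbon. The same kind of change has already been made once among the measured compounds, from compound 2 to compound 1: hydrogen in place of chloro on an aromatic carbon. That step gave a 1.7-fold higher number from compound 2 to compound 1 (0.24 log units; within the scatter). The surroundings are not identical, though: in compound 2 the leaving chloro sits ortho to a large group and meta to a chloro group, whereas in compound 3 it sits para to a large group, so this is the same kind of change rather than the same change.

Because the earlier step of a 1.7-fold higher number from compound 2 to compound 1 (0.24 log units; within the scatter) stayed within the scatter, compound 4 is expected to land close to compound 3, with the step estimated as a 1.7-fold higher number from compound 3 to compound 4 (0.23 log units; within the scatter). The expected value for compound 4 in this assay is 7000 nM, with a range from 2500 nM to 20000 nM.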

Compound 4, half-maximal inhibitory concentration: 2480 nM
Compound 4: middle estimate off by 2.8-fold (0.45 log units), on the high side; measured number outside the range, below it.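

In this assay the same replacement of chloro by hydrogen, here the 4-chlorophenyl to phenyl change on the core of compound 3, gave a 1.7-fold lower number from compound 3 to compound 4 (0.22 log units; within the scatter) and so ran the opposite way to the earlier step. Each step is small taken alone, but the two do not match once set side by side: the same change on two cores in this assay, a 1.7-fold higher number (0.24 log units; within the scatter) from compound 2 to compound 1 and a 1.7-fold lower number (0.22 log units; within the scatter) from compound 3 to compound 4, 2.8-fold (0.45 log units) apart, beyond the scatter of two such steps. Among these compounds, this shows that the number obtained for this change on one core could not simply be carried over to the other core, but it does not show why, since there is only one pair per core, the cores differ in more than one place, and the chloro groups sit in different surroundings on their rings.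

The compounds shown leave open how a fluoro group, a methoxy group or an amine in place of the chloro group of compound 3 would read in this assay. They also leave open whether replacing chloro by hydrogen on a third core would follow either of these two steps, and whether the mismatch seen here would hold up with more pairs on each core.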